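Notes on the step from compound 1 to compound 4

The source may report more compounds than this note shows. Statements on the series, on what has been measured and on what is new or still open speak of the compounds shown alone.

Compound 1 `COc1cc(C(=O)/C=C/c2cc(O)ccc2O)cc(OC)c1OC`: > 100000 nM
Compound 2 `COc1cc(C(=O)/C=C/c2ccc([N+](=O)[O-])cc2)cc(OC)c1OC`: 43000 nM
Compound 3 `COc1cc(C(=O)/C=C/c2cc([N+](=O)[O-])ccc2O)cc(OC)c1OC`: 76000 nM

In a functional assay on COLO 205 cells (Homo sapiens) for inhibition, read by MTT assay, with a stated time of 48 h (on this read-out higher numbers stand for weaker inhibition and lower numbers for stronger inhibition), compound 1 stands at > 100000 nM, which is a limit and not a number. Compound 1 therefore sits at the limit of > 100000 nM in this assay, at which 1 of the 3 values shown sits. Compound 2 gives 43000 nM and compound 3 gives 76000 nM, and these two values lie within the usual scatter of each other.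

Compound 4 `COc1cc(C(=O)/C=C/c2ccccc2C=O)cc(OC)c1OC` has not yet been measured. The change is 2-formylphenyl in place of 2,5-dihydroxyphenyl on a double-bonded chain carbon bound to a double-bonded chain carbon.

Among the compounds with values here, the only measured step that bears on it is an at least 1.3-fold lower number from compound 1 to compound 3 (0.11 log units; that floor lies within the scatter). Within the data shown here, that step is a nitro in place of hydroxy, so it covers only part of the present change, and no measured compound carries the 2-formylphenyl group. Compound 2, which also lacks the 2,5-dihydroxyphenyl group, gives 43000 nM, and this supports an expectation of a measurable number. In this assay, a modest move toward stronger inhibition is therefore expected, with the starting point known only as a limit. The expected step is an at least 2.5-fold lower number from compound 1 to compound 4 (0.39 log units; beyond the scatter). For compound 4 the estimated value is 40000 nM, with an expected range of 12000 nM to 100000 nM.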

Compound 4, half-maximal inhibitory concentration: 88000 nM
The estimate for compound 4 lay 2.2-fold (0.34 log units) below the measured number; the measured number falls inside the stated range.
By their numbers in this assay, from the lowest: compounds 2, 3 and 4 (each within the scatter of the next, the first and the last beyond it). At a limit, above all of these: compound 1.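

In this assay, 2-formylphenyl in place of 2,5-dihydroxyphenyl on a double-bonded chain carbon bound to a double-bonded chain carbon gives an at least 1.1-fold lower number from compound 1 to compound 4 (0.05 log units; that floor lies within the scatter), so this change supports no claim of a real gain at this position. Compound 1 stands at a limit and not a number: the limit of > 100000 nM in this assay, at which 1 of the 4 values shown sits. What compound 4 adds is that a measurable number at this position does not depend on keeping any hydroxy group or on a nitro group, since compound 4 carries neither, whereas compound 2 and compound 3 both carry a nitro group and compound 3 also keeps a hydroxy group.

As far as these compounds go, the true size of the step remains open, as only its floor can be read, and so does the part played by the formyl group itself, which only an unsubstituted phenyl at this place could separate from the loss of the 2,5-dihydroxyphenyl group. Also open, from the compounds shown here alone, is whether a carboxylic acid or an aminomethyl group in place of the formyl group would give a number beyond the scatter of the values for compound 2, compound 3 and compound 4.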